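From Pyridyl Urea to Phenyl Urea: One Ring Atom Changed

The source may hold more compounds than are shown below. What is called first, only, known or untested is meant among the compounds shown, and "the series" means these compounds.

Measured so far:
compound 1, `Cc1cc(CNC(=O)c2cc(Cl)nc(Cl)c2)ncc1-c1cn(C)nc1C`, > 19000 nM
compound 2, `Cc1cc(CNC(=O)Nc2cc(Cl)nc(Cl)c2)ncc1-c1cn(C)nc1C`, 300 nM

Both compounds were tested in a functional assay on CHO cells for antagonist activity at sphingosine 1-phosphate receptor 2 (Homo sapiens), read by fluorescence and calcium flux, with a stated time of 3 min; a higher number here means a weaker inhibitor, a lower number a stronger inhibitor. For compound 1 the result is a limit of the assay rather than a number; compound 1 gave > 19000 nM. For the measured compounds named here, compound 2 gave 300 nM, which is the only true number in the set. Going by the values given here, the one step between them, an at least 63-fold lower number from compound 1 to compound 2 (1.80 log units; beyond the scatter), swaps the 2,6-dichloropyridin-4-yl group on the carbonyl carbon for a (2,6-dichloropyridin-4-yl)amino group, turning an amide into a urea; the size of that step can only be given as a bound because of the limit of > 19000 nM in this assay, at which 1 of the 2 values shown sits.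

Compound 3, `Cc1cc(CNC(=O)Nc2cc(Cl)cc(Cl)c2)ncc1-c1cn(C)nc1C`, keeps the urea of compound 2 and changes only the ring attached to it: 3,5-dichlorophenyl in place of 2,6-dichloropyridin-4-yl on an amide-type nitrogen. Among the compounds with values here, no measured step touches a change of this kind; the single known step concerns the amide-to-urea link, not the ring. Without a guide, the expectation for compound 3 is a step of a 1.3-fold higher number from compound 2 to compound 3 (0.12 log units; within the scatter), within the scatter. Compound 3 is therefore estimated at 400 nM, with a range from 100 nM to 1600 nM.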

Compound 3, half-maximal inhibitory concentration: 160 nM
Estimate against measurement, compound 3: 2.5-fold (0.40 log units) above; measured number inside the range.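

Replacing 2,6-dichloropyridin-4-yl with 3,5-dichlorophenyl on the amide-type nitrogen gives a 1.9-fold lower number from compound 2 to compound 3 (0.27 log units; within the scatter), so in this assay these two ureas cannot be told apart, and the ring nitrogen of compound 2 is not required for a urea of this series to show activity. The earlier gain from the urea link also holds with the carbon-only ring, as the comparison with the amide gives an at least 110-fold lower number from compound 1 to compound 3 (2.07 log units; beyond the scatter). That step can be stated only as a bound because compound 1 sits at a limit of the assay rather than at a true number: the limit of > 19000 nM in this assay, at which 1 of the 3 values shown sits.

The compounds shown leave open whether other groups on this ring, such as methoxy or trifluoromethyl in place of the chlorine atoms, or a phenyl ring with no chlorine at all, would move the number beyond the scatter. They also leave open whether a carbamate could stand in for the urea link and keep the activity that separates the ureas from the amide.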